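The compounds below may be only part of what the source reports. "The series", "measured", "known", "first", "only" and "open" are said of these compounds alone.

In a functional assay on DU-145 cells (Homo sapiens) for antiproliferative activity, read by MTT assay (on this read-out lower numbers stand for stronger inhibition and higher numbers for weaker inhibition), compound 1 (`Fc1ccc(N2CCN(c3nc(-n4ccc5ccccc54)c4ccccc4n3)CC2)cc1`) gives 50 ug/mL. Compound 2 (`COc1cc(OC)c(-c2nc(N3CCN(C)CC3)nc3ccccc23)c(OC)c1`) gives 50 ug/mL and compound 3 (`Cn1cc(-c2nc(N3CCNCC3)nc3ccccc23)c2ccccc21`) gives 50 ug/mL, so compound 1 stands level with both. Compound 4 (`c1ccc(N2CCN(c3nc(-n4ccc5ccccc54)c4ccccc4n3)CC2)nc1`) carries pyridin-2-yl in place of 4-fluorophenyl on an amine nitrogen in a ring. Among the compounds with values here, no measured pair shows what a single change does here, so the guide is thin. It consists of compound 1 at 50 ug/mL and the matching readings of two differently built compounds. The expected result is no change at the digits printed from compound 1 to compound 4 (within the scatter), which means no step beyond the scatter in either direction. In this assay, the estimate for compound 4 is 50 ug/mL, with an expected range from 25 ug/mL to 100 ug/mL.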

Compound 4, half-maximal inhibitory concentration: 50 ug/mL
Compound 4: the middle estimate sits on the measured number at the digits printed; low and high end bracket the measured number.
By their numbers in this assay, from the lowest: compounds 1, 2, 3 and 4 (each within the scatter of the next).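

Pyridin-2-yl in place of 4-fluorophenyl on this ring amine nitrogen gives, in this assay, no change at the digits printed from compound 1 to compound 4 (within the scatter) as the first single-change step in the set. At this place, then, a ring with a hetero atom and a hydrogen-bond acceptor reads the same as the carbon-only ring bearing fluorine. No measured evidence accounts for this result. Still open, from the compounds shown here alone, is whether a group of another kind at this place, such as a benzyl group or a carboxylic acid on the ring, would shift the reading.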